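The source may hold more compounds than are shown below. What is called first, only, known or untested is meant among the compounds shown, and "the series" means these compounds.

Among the compounds with values here, the two compounds measured so far share a core and differ in the side chain on the saturated ring. Compound 1 `CC(=O)NCC[C@@H]1C[C@@H](c2ccc(F)c(F)c2)[C@H](NC(=O)c2cc(-c3c(Cl)cnn3C)c(Cl)o2)CN1` carries an acetamide on a two-carbon chain, and in a functional assay on LNCaP cells (Homo sapiens) for antiproliferative activity (on this read-out lower numbers stand for stronger inhibition and higher numbers for weaker inhibition), compound 1 gives 130 nM. Compound 2 `Cn1ncc(Cl)c1-c1cc(C(=O)N[C@@H]2CN[C@H](CC(=O)O)C[C@H]2c2ccc(Cl)c(Cl)c2)oc1Cl` carries a carboxymethyl group instead, and in this assay compound 2 gives 640 nM. Of the two numbers, that of compound 2 is the higher one, and the gap to compound 1 lies beyond the scatter of repeated measurements.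

Compound 3 `Cn1ncc(Cl)c1-c1cc(C(=O)N[C@@H]2CN[C@H](CC(=O)NC3CCC3)C[C@H]2c2ccc(Cl)c(Cl)c2)oc1Cl` takes the carboxymethyl group of compound 2 one step further: cyclobutylamino in place of hydroxy on a carbonyl carbon. Cut one bond further out, the change reads carboxy to cyclobutylcarbamoyl.

Within the data shown here, no measured pair in this set shows the effect of such a change directly. Among the measured compounds shown here, the only hint is that compound 1, whose side chain ends in an amide rather than an acid, gives 130 nM, a lower number than compound 2. On that basis a modest step toward lower numbers is expected from compound 2 to compound 3, a 2.3-fold lower number from compound 2 to compound 3 (0.36 log units; beyond the scatter), probably near the edge of the scatter. In this assay compound 3 is therefore estimated at 280 nM, with a plausible range from 90 nM to 900 nM.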

Compound 3, half-maximal inhibitory concentration: 80 nM
For compound 3 the middle estimate is 3.5-fold (0.54 log units) above the measured one; measured number outside the range, below it.
By their numbers in this assay, from the lowest: compounds 3 and 1 (each within the scatter of the next); then compound 2.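

In this assay, within the data shown here, cyclobutylamino in place of hydroxy on a carbonyl carbon gives an 8.0-fold lower number from compound 2 to compound 3 (0.90 log units; beyond the scatter), and this is the first step in the set that reads a single change directly. It shows that the carboxy end of the carboxymethyl side chain can be replaced by cyclobutylcarbamoyl, with its four-membered carbon ring, and that the number then falls rather than rises. No measurement shown here accounts for the size of this step.

The compounds shown leave open whether the lower number goes with the amide itself or with the cyclobutyl ring, a question that an unsubstituted carboxamide, a methylamino group or a cyclopentylamino group on the same carbonyl carbon would help to settle. They also leave open whether (cyclobutylcarbamoyl)methyl is the best length for this side chain, since a longer chain between the saturated ring and the carbonyl carbon, or a tertiary amide such as a pyrrolidine amide, does not appear among them.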